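The source may hold more compounds than are shown below. What is called first, only, known or untested is meant among the compounds shown, and "the series" means these compounds.

Compound 1 `CC(C)c1ccccc1/C=C/C(=O)c1ccccc1`: in an ADME assay on cells (Epithelial cell, Homo sapiens) for cytotoxicity, read by MTT assay, with a stated time of 44 h (a lower number here means a stronger inhibitor, a higher number a weaker inhibitor), compound 1 gives > 46000 nM, which is a limit of the assay and not a number.
Compound 2 `CC(C)c1ccccc1C1CC(c2ccccc2)=NN1C(N)=S`: in this assay compound 2 gives > 50000 nM, again a limit.
Compound 3 `O=C(/C=C/c1ccccc1Cl)c1ccccc1`: in this assay compound 3 gives > 50000 nM, likewise a limit.

From compound 1 to compound 3 the change is chloro in place of isopropyl on an aromatic carbon -like in kind; more exactly, it is chloro in place of isopropyl on an aromatic carbon. The step that the two limits leave unreadable from compound 1 to compound 3 cannot be read because the limit of > 46000 nM in this assay, at which 1 of the 3 values shown sits, bounds one end and the limit of > 50000 nM in this assay, at which 2 of the 3 values shown sit, bounds the other. Compound 2 differs from compound 1 in its core, and the difference between the two cores is not broken down here.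

Compound 4 `NC(=S)N1N=C(c2ccccc2)CC1c1ccccc1Cl` has not yet been measured in this assay. It differs from compound 2 by the same change, made at the same place. Since both ends of the earlier step rest at limits, there is nothing to show that this change moves the read-out, and compound 2 itself sits at a limit. The step from compound 2 to compound 4 is therefore expected to be a number no higher from compound 2 to compound 4 (the limit leaves the size open), essentially none. Compound 4 is expected at about 50000 nM, between 20000 nM and 120000 nM, most likely reported again only as a limit.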

Compound 4, half-maximal inhibitory concentration: > 50000 nM
Compound 4: a limit, no number; the forecaster's own chance of this, stated with the estimate: 85%; the middle value lies on the limit itself.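

The step between compound 2 and compound 4 cannot be read in this assay, since each compound rests at the same limit and neither gives a number: the limit of > 50000 nM in this assay, at which 3 of the 4 values shown sit.

The compounds shown leave open whether chloro in place of isopropyl on an aromatic carbon changes the read-out on either core, and where the true half-maximal concentration of any of them lies.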